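A few compounds are considered here, and "the series" means these few. Any claim that something is new, unique, unknown or untested is made for them only; others in the source may bear on it.

Measured in a functional assay on HT29-AK cells (Homo sapiens) for cytotoxicity, read by MTT assay, with a stated time of 48 h; a lower number here means a stronger inhibitor, a higher number a weaker inhibitor:
- compound 1 `Fc1ccc2nc(-c3ccccc3)nc(Nc3ccccc3)c2c1`: > 50000 nM (a limit)
- compound 2 `Fc1cccc(-c2nc(Nc3ccccc3)c3cc(F)ccc3n2)c1`: 48300 nM
- compound 3 `Fc1cccc(-c2nc(Nc3ccccc3F)c3cc(F)ccc3n2)c1`: > 50000 nM (a limit)

Compound 3 has no number on this assay, only the limit > 50000 nM. Across the series the data show (the limit of > 50000 nM in this assay, at which 2 of the 3 values shown sit).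

Compound 4 `Oc1ccc(Nc2nc(-c3cccc(F)c3)nc3ccc(F)cc23)cc1` differs from compound 3 in one place: 4-hydroxyphenyl in place of 2-fluorophenyl on a nitrogen on an aromatic ring. This puts 4-hydroxyphenyl in place of 2-fluorophenyl on a nitrogen on an aromatic ring.

Two measured steps lie nearby, both fluoro in place of hydrogen on an aromatic carbon: an at least 1.0-fold lower number from compound 1 to compound 2 (0.01 log units; that floor lies within the scatter) and an at least 1.0-fold higher number from compound 2 to compound 3 (0.01 log units; that floor lies within the scatter). Neither goes beyond the scatter, and neither introduces a hydroxy group, so they offer only weak guidance for this change.

Within the data shown here, with compound 2 at 48300 nM as the only number, the expectation stays close to that level, with a modest move towards a lower number at most. The expected change is an at least 1.6-fold lower number from compound 3 to compound 4 (0.22 log units; that floor lies within the scatter). A further limit reading would not be surprising. For compound 4 the estimated value is 30000 nM, with an expected range from 7000 nM to 50000 nM.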

Compound 4, half-maximal inhibitory concentration: > 50000 nM
Compound 4: a limit, no number; the forecaster's own chance of this, stated with the estimate: 35%; middle value at least 1.6-fold (0.22 log units) from the limit.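

In this assay compound 4 gives > 50000 nM, which is a limit and not a number, and the step between the two limits of compound 3 and compound 4 cannot be read. Adding a hydroxy group alone gives an at least 1.0-fold higher number from compound 2 to compound 4 (0.01 log units; that floor lies within the scatter), so adding a hydrogen-bond donor and acceptor at this position produces no change that can be told from the scatter. Compound 2 alone carries a number, and the hydroxy compound joins the others at the limit: the limit of > 50000 nM in this assay, at which 3 of the 4 values shown sit.

Going by these compounds, whether an amine or a carboxylic acid on the ring attached to this nitrogen would give a value clearly clear of the limit stays open. Also open, on these data alone, is whether a methoxy group in place of the hydroxy group would read any differently in this assay.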